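This account rests on a few compounds, and the source may have more. Where it says the series, first, only, none or still open, it means among the compounds named here.

Measured compounds:
compound 1 `COC(=O)C1=C(C)NC(C)=C(C(=O)OCCCl)C1c1cccc([N+](=O)[O-])c1`, in a functional assay on HEK293 cells for antagonist activity at Voltage-dependent L-type calcium channel subunit alpha-1C (Oryctolagus cuniculus), read by FLIPR (on this read-out lower numbers stand for stronger inhibition and higher numbers for weaker inhibition), compound 1 gives 26 nM;
compound 2 `COC(=O)C1=C(C)NC(C)=C(C(=O)OCCc2ccc(Cl)cc2)C1c1cccc([N+](=O)[O-])c1`, in this assay compound 2 gives 8 nM.

Going by the values given here, compound 2 holds the lower of the two numbers, with compound 1 the only comparison: a 3.3-fold lower number from compound 1 to compound 2 (0.51 log units; beyond the scatter). Compound 3 `COC(=O)C1=C(C)NC(C)=C(C(=O)OCCCOc2ccccc2)C1c1cccc([N+](=O)[O-])c1` differs from compound 2 by phenoxymethyl in place of 4-chlorophenyl on a saturated chain carbon, two bonds along the chain from an oxygen next to a carbonyl group. Among the compounds with values here, no measured step covers this exchange of one aromatic group for another at the same place; the only step, from compound 1 to compound 2, shows that an aromatic group here lowered the number, and compound 3 keeps an aromatic group. A step within the scatter is therefore expected, a 1.3-fold higher number from compound 2 to compound 3 (0.10 log units; within the scatter). Compound 3 is estimated at 10 nM, range 4 nM to 25 nM.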

Compound 3, half-maximal inhibitory concentration: 9 nM
For compound 3 the middle estimate is 1.1-fold (0.05 log units) above the measured one; low and high end bracket the measured number.
By their numbers in this assay, from the lowest: compounds 2 and 3 (each within the scatter of the next); then compound 1.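

Exchanging 4-chlorophenyl for phenoxymethyl on this saturated chain carbon gives a 1.1-fold higher number from compound 2 to compound 3 (0.05 log units; within the scatter) in this assay and so leaves the two aromatic groups indistinguishable, despite the chlorine leaving and an oxygen entering. Phenoxymethyl in place of chloro gives a 2.9-fold lower number from compound 1 to compound 3 (0.46 log units; beyond the scatter) and shows that the lower number seen with 4-chlorophenyl is not confined to that one aromatic group. No available evidence bears on this result.

Open, going by these compounds, is whether an amine or a carboxylic acid at this place would keep the number at this level. On these data alone, a longer chain carrying the phenyl ring also remains open.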